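Swapping Methyl for Methoxy on an Aromatic Carbon

This account rests on a few compounds, and the source may have more. Where it says the series, first, only, none or still open, it means among the compounds named here.

Within the data shown here, in a functional assay on NB-4 cells (Homo sapiens) for cytotoxicity, read by CCK-8 assay, with a stated time of 24 h (on this read-out higher numbers stand for weaker inhibition and lower numbers for stronger inhibition), compound 1 `C=CC(=O)N1C(=O)CC(c2ccc(C(F)(F)F)cc2)Sc2ccccc21` gives 38600 nM and compound 2 `C=CC(=O)N1C(=O)CC(c2ccc(C)cc2)Sc2ccccc21` gives 37300 nM, so compound 2 stands level with its only measured neighbour. Compound 3 `C=CC(=O)N1C(=O)CC(c2ccc(OC)cc2)Sc2ccccc21` has methoxy in place of methyl on an aromatic carbon. Among the measured compounds shown here, one measured step bears on this, the exchange of trifluoromethyl for methyl at the same place, a 1.0-fold lower number from compound 1 to compound 2 (0.01 log units; within the scatter). On that single step, no change beyond the scatter is expected in this assay. The estimated step is a 1.0-fold lower number from compound 2 to compound 3 (0.00 log units; within the scatter). The expected value for compound 3 is 37000 nM, with an estimated range of 20000 nM to 65000 nM.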

Compound 3, half-maximal inhibitory concentration: 32900 nM
Estimate against measurement, compound 3: 1.1-fold (0.05 log units) above; the measured number falls inside the stated range.
By their numbers in this assay, from the lowest: compounds 3, 2 and 1 (each within the scatter of the next).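

Three different groups on this aromatic carbon now read alike in this assay: methoxy in place of methyl gives a small step (a 1.1-fold lower number from compound 2 to compound 3 (0.05 log units; within the scatter)), and methoxy in place of trifluoromethyl gives another (a 1.2-fold lower number from compound 1 to compound 3 (0.07 log units; within the scatter)). The earlier pair held no hydrogen-bond acceptor in this group, and adding one here leaves the number within the scatter. Nothing available explains this result. Still open, on these data alone, is whether an amine, a carboxylic acid or a longer chain such as ethoxy at this place would move the number beyond the scatter.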